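Replacing an aryl group with methyl on the shared core

A few compounds are considered here, and "the series" means these few. Any claim that something is new, unique, unknown or untested is made for them only; others in the source may bear on it.

In a functional assay on K562 cells (Homo sapiens) for antiproliferative activity, read by MTT assay, with a stated time of 48 h (a higher number here means a weaker inhibitor, a lower number a stronger inhibitor), compound 1 `O=C(CCCCCCn1cc(Nc2ncc(Cl)c(Nc3cccc(Cl)c3)n2)cn1)NO` gives 380 nM. Compound 2 `COc1ccc(Nc2nc(Nc3cnn(CCCCCCC(=O)NO)c3)ncc2Cl)cc1` gives 620 nM, which lies within the usual scatter of the compound 1 value, so neither compound can be ranked above the other.

Compound 3 `CNc1nc(Nc2cnn(CCCCCCC(=O)NO)c2)ncc1Cl` differs from compound 2 in one place: methyl in place of 4-methoxyphenyl on a nitrogen on an aromatic ring. Methyl takes the place of 4-methoxyphenyl on a nitrogen on an aromatic ring, so the aromatic ring of that group is lost.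

For the measured compounds named here, only one measured step bears on this: a 1.6-fold higher number from compound 1 to compound 2 (0.21 log units; within the scatter). Going by the values given here, that step only exchanged 3-chlorophenyl for 4-methoxyphenyl, and no measured compound lacks such a ring, so it is a weak guide. A modest move to a higher number in this assay, meaning a weaker inhibitor, is expected. The expected step is a 2.4-fold higher number from compound 2 to compound 3 (0.38 log units; beyond the scatter). For compound 3 the estimate is 1500 nM, with an expected range of 500 nM to 4500 nM.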

Compound 3, half-maximal inhibitory concentration: 590 nM
Estimate against measurement, compound 3: 2.5-fold (0.41 log units) above; the range from low to high includes it.
By their numbers in this assay, from the lowest: compounds 1, 3 and 2 (each within the scatter of the next).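

Methyl on this nitrogen carries no ring at all, yet in this assay the change gives a 1.1-fold lower number from compound 2 to compound 3 (0.02 log units; within the scatter) and the change from 3-chlorophenyl gives a 1.6-fold higher number from compound 1 to compound 3 (0.19 log units; within the scatter) as well, so on this core an aromatic ring in this group is not required for a value in this range. The earlier step only exchanged one aryl group for another, so it could not show this: all three compounds now lie within the scatter of one another, whether the nitrogen bears an aryl group or methyl. Nothing available here explains this result.

As far as these compounds go, it remains open whether any other group on this nitrogen would move the number beyond the scatter, such as a plain amine with no carbon substituent, a longer chain like butyl, or a saturated ring like cyclohexyl. All three compounds also share the same core and side chain, so the result may not carry over to other cores or chains.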